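Bromo for chloro on a second sulfonamide core

This account rests on a few compounds, and the source may have more. Where it says the series, first, only, none or still open, it means among the compounds named here.

Measured compounds:
compound 1 `O=S(=O)(Nc1ccccc1)c1ccc(Cl)cc1` — 8.47
compound 2 `O=S(=O)(Nc1ccccc1)c1ccc(Br)cc1` — 8.5
compound 3 `O=S(=O)(Nc1ccc(F)cc1)c1ccc(Cl)cc1` — 8.41

Three sulfonamides have been measured in an ADME assay. Compound 1 and compound 2 share one core and differ by bromo in place of chloro on an aromatic carbon; that change gave a number 0.03 log units higher from compound 1 to compound 2 (within the scatter). Compound 3 differs from compound 1 by fluoro in place of hydrogen on an aromatic carbon, and the step of a number 0.06 log units lower from compound 1 to compound 3 (within the scatter) was recorded. Compound 4 `O=S(=O)(Nc1ccc(F)cc1)c1ccc(Br)cc1` has not yet been measured in this assay. It stands to compound 3 as compound 2 stands to compound 1, differing by bromo in place of chloro on an aromatic carbon, the same change seen once before among these compounds. Since the earlier instance of this change gave a number 0.03 log units higher from compound 1 to compound 2 (within the scatter), a step of similar size is expected from compound 3 to compound 4, namely a number 0.03 log units higher from compound 3 to compound 4 (within the scatter). Compound 4 is therefore estimated at 8.44, between 8.2 and 8.7.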

Compound 4, acid dissociation constant: 8.38
Compound 4: middle estimate off by 0.06 log units, on the high side, within the range that was stated.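

In this assay, bromo in place of chloro gave a number 0.03 log units lower from compound 3 to compound 4 (within the scatter), and fluoro in place of hydrogen gave a number 0.12 log units lower from compound 2 to compound 4 (within the scatter). For bromo in place of chloro, the two cores agree: the same change on two cores in this assay, a number 0.03 log units higher (within the scatter) from compound 1 to compound 2 and a number 0.03 log units lower (within the scatter) from compound 3 to compound 4, 0.06 log units apart, within the scatter of two such steps. Fluoro in place of hydrogen also agrees across the cores, but this shows only that neither change produced a step beyond the scatter on these cores, not that either change has a consistent direction: the same change on two cores in this assay, a number 0.06 log units lower (within the scatter) from compound 1 to compound 3 and a number 0.12 log units lower (within the scatter) from compound 2 to compound 4, 0.06 log units apart, within the scatter of two such steps.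

The compounds shown carry only chloro, bromo and fluoro as substituents. As far as these compounds go, it remains open whether an amine or a carboxylic acid at these places would give a step beyond the scatter, and whether such a step would carry from one core to the other.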